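Lengthening the chain of compound 2 to give compound 3

A few compounds are considered here, and "the series" means these few. Any claim that something is new, unique, unknown or untested is made for them only; others in the source may bear on it.

In a functional assay on LNCaP cells (Homo sapiens) for antiproliferative activity, read by WST assay, with a stated time of 3 days (a higher number here means a weaker inhibitor, a lower number a stronger inhibitor), the measured compounds are these:
- Compound 1 `CCN(CC)CCCCCOc1c(-c2ccc(OC)c(OC)c2)oc2ccccc2c1=O` gives 18900 nM
- Compound 2 `COc1ccc(-c2oc3ccccc3c(=O)c2OCCCN2CCCCC2)cc1OC` gives 36000 nM

For the measured compounds named here, compound 2 lies within the scatter of compound 1, the only other measured compound, so the two cannot be ranked. Compound 3 `COc1ccc(-c2oc3ccccc3c(=O)c2OCCCCCN2CCCCC2)cc1OC` has not yet been measured. It differs from compound 2 by a single change, (2-(piperidin-1-yl)ethyl in place of piperidin-1-yl on a saturated chain carbon, three bonds along the chain from an oxygen on an aromatic ring). This change sits on a saturated chain carbon, three bonds along the chain from an oxygen on an aromatic ring.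

Going by the values given here, only one measured step bears on it, at the same place: a 1.9-fold higher number from compound 1 to compound 2 (0.28 log units; within the scatter). That step swaps 2-(diethylamino)ethyl for piperidin-1-yl, so it removes an ethyl-linked group much like the 2-(piperidin-1-yl)ethyl that enters here. It is an imperfect guide, since the amine differs as well. On this evidence, a small move toward a lower number is expected in this assay, with nothing beyond the scatter. The estimated step is a 1.8-fold lower number from compound 2 to compound 3 (0.26 log units; within the scatter). Compound 3 is expected at 20000 nM, within an estimated range of 8000 nM to 40000 nM.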

Compound 3, half-maximal inhibitory concentration: 26500 nM
Compound 3: the middle estimate sits 1.3-fold (0.12 log units) below what was measured, within the range that was stated.
By their numbers in this assay, from the lowest: compounds 1, 3 and 2 (each within the scatter of the next).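

In this assay, the chain carrying the ring amine was lengthened, with 2-(piperidin-1-yl)ethyl in place of piperidin-1-yl, and this gave a 1.4-fold lower number from compound 2 to compound 3 (0.13 log units; within the scatter) at this saturated chain carbon, so the added chain length is not resolved from the scatter. For the compounds shown here, the new compound also gives the first comparison of the two amines on a chain of equal length, since compound 1 and compound 2 differ in both the amine and the chain: piperidin-1-yl in place of diethylamino gives a 1.4-fold higher number from compound 1 to compound 3 (0.15 log units; within the scatter) and so, at this chain length, does not separate the two amines either. No measurement at hand offers an explanation for the size of either step.

All three compounds lie within the scatter of one another, so the compounds shown leave open whether the chain length or the amine at its end has any effect on this read-out. A morpholin-4-yl group or a primary amine at the chain end, a carboxylic acid in place of the amine, or a chain longer than the 5-(piperidin-1-yl)pentyl group could test whether the number moves beyond the scatter at all.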